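This account rests on a few compounds, and the source may have more. Where it says the series, first, only, none or still open, it means among the compounds named here.

In a functional assay on HepG2 cells (Homo sapiens) for antiproliferative activity, read by MTT assay, with a stated time of 48 h (a higher number here means a weaker inhibitor, a lower number a stronger inhibitor), compound 1 `CCCC(C)Oc1ccc(C(=O)/C=C/c2c(/C=C/c3ccc(OC)cc3)cc(OC)cc2OC)cc1` gives 11.1 ug/mL. Two close relatives differ from it only in the group on one aromatic carbon: compound 2 `COc1ccc(/C=C/c2cc(OC)cc(OC)c2/C=C/C(=O)c2ccc(C)cc2)cc1` gives 4.8 ug/mL and compound 3 `COc1ccc(/C=C/c2cc(OC)cc(OC)c2/C=C/C(=O)c2ccc(N)cc2)cc1` gives 7.5 ug/mL. Compound 1 therefore carries the highest of the three numbers, although its gap to compound 3 lies within the scatter and only its gap to compound 2 is wider. That wider move is a 2.3-fold lower number from compound 1 to compound 2 (0.36 log units; beyond the scatter), whereas a 1.5-fold lower number from compound 1 to compound 3 (0.17 log units; within the scatter) and a 1.6-fold higher number from compound 2 to compound 3 (0.19 log units; within the scatter) both stay inside the scatter.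

Compound 4 `CCOc1ccc(C(=O)/C=C/c2c(/C=C/c3ccc(OC)cc3)cc(OC)cc2OC)cc1` is the next candidate. It differs from compound 1 by hydrogen in place of propyl on a saturated chain carbon bound to an oxygen on an aromatic ring and a saturated chain carbon, so the 1-methylbutoxy group is shortened to ethoxy rather than swapped for something else. The measured steps bear on the same aromatic carbon, but each of them removes the whole group in favour of methyl or amino, and even the larger of them was only modest. Trimming the chain while keeping the oxygen seems likely to matter less than either of those swaps. For compound 4 the expected step is a 1.2-fold lower number from compound 1 to compound 4 (0.09 log units; within the scatter), a change that is estimated to fall within the scatter, leaning if anything towards a lower number. Compound 4 is accordingly estimated at 9 ug/mL, with a range from 4.5 ug/mL to 18 ug/mL.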

Compound 4, half-maximal inhibitory concentration: 8 ug/mL
For compound 4 the middle estimate is 1.1-fold (0.05 log units) above the measured one; the measured number falls inside the stated range.
By their numbers in this assay, from the lowest: compounds 2, 3, 4 and 1 (each within the scatter of the next, the first and the last beyond it).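

In this assay, within the data shown here, shortening 1-methylbutoxy to ethoxy while keeping the oxygen gives a 1.4-fold lower number from compound 1 to compound 4 (0.14 log units; within the scatter), so this is the first view of the chain alone at this position, and trimming it leaves the reading inside the normal spread of repeat measurements. Ethoxy also cannot be told apart from either smaller group on the same aromatic carbon, as shown by a 1.1-fold higher number from compound 3 to compound 4 (0.03 log units; within the scatter) and by a 1.7-fold higher number from compound 2 to compound 4 (0.22 log units; within the scatter); compound 4 thus lies within the scatter of both compound 1 and compound 2, even though those two are separated by a gap beyond it, and the one clear gap in this set does not divide the compounds into two distinct groups. No measurement available here explains why these numbers fall as they do.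

Going by these compounds, whether the branch or the length of the chain matters more remains open, and a straight butoxy chain would be the natural comparison with 1-methylbutoxy. Also open, on these data alone, is how a hydroxyl group or a carboxylic acid on the same aromatic carbon would read against methyl, amino and ethoxy.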